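One stereocentre inverted: compound 2 and compound 3

This account rests on a few compounds, and the source may have more. Where it says the series, first, only, none or still open, it means among the compounds named here.

Compound 1 `O=C1C=CC[C@H]([C@@H]2C[C@H]2c2ccccc2)O1`: 62800 nM
Compound 2 `O=C1C=CC[C@@H](/C=C/C2CCCCC2)O1`: 68600 nM

In a functional assay on A549 cells (Homo sapiens) for antiproliferative activity, read by luminescence and CellTiter-Glo, with a stated time of 48 h (on this read-out lower numbers stand for stronger inhibition and higher numbers for weaker inhibition), compound 2 gives 68600 nM and so stands within the scatter of compound 1, which gives 62800 nM in the same test. The unmeasured compound 3 `O=C1C=CC[C@H](/C=C/C2CCCCC2)O1` has the same atoms and bonds as compound 2 (the two compounds have the same atoms and bonds and differ only in configuration as drawn: 1 of 2 stereo elements differ; a stereocentre at a saturated ring carbon is drawn S in compound 2 and R in compound 3), with a stereocentre at a saturated ring carbon drawn S in compound 2 and R in compound 3. Among the measured compounds shown here, no measured pair shows what such a change does in this assay, so no direction can be argued from the data. The expected size of a 1.2-fold lower number from compound 2 to compound 3 (0.10 log units; within the scatter) is therefore none beyond the scatter, though a wide margin is kept on both sides. Compound 3 is estimated at 55000 nM with an expected range from 15000 nM to 130000 nM in this account.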

Compound 3, half-maximal inhibitory concentration: 31000 nM
Estimate against measurement, compound 3: 1.8-fold (0.25 log units) above, within the range that was stated.
By their numbers in this assay, from the lowest: compound 3; then compounds 1 and 2 (each within the scatter of the next).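

In this assay, the inversion gives a 2.2-fold lower number from compound 2 to compound 3 (0.34 log units; beyond the scatter), so the configuration at this saturated ring carbon has a measurable effect on the read-out, with the compound drawn R giving the lower number. The step is modest, but it lies beyond the scatter, which the earlier values could not have shown since no measured pair isolated this change. The difference can be assigned to this stereocentre alone, and not to any change of substituent, because of: the fact that compounds 2 and 3 differ only in the configuration as drawn

The compounds shown leave open whether inverting this stereocentre would have a similar effect with the side chain of compound 1 in place. They also leave open how the number in this assay would respond if an amine, a carboxylic acid or a longer chain were carried on the side chain of compound 3.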